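The source may report more compounds than this note shows. Statements on the series, on what has been measured and on what is new or still open speak of the compounds shown alone.

Values in a functional assay on UMUC3 cells (Homo sapiens) for antiproliferative activity, read by MTT assay, with a stated time of 72 h; a lower number here means a stronger inhibitor, a higher number a weaker inhibitor:
- Compound 1 `CC(C)NC(=N)NC(=N)Nc1ccc(F)c(F)c1`: 25000 nM
- Compound 2 `CC(C)NC(=N)NC(=N)Nc1ccc(F)cc1`: > 50000 nM, which is a limit of the assay and not a number
- Compound 3 `CCN(CC)C(=N)NC(=N)Nc1ccc(C(F)(F)F)cc1`: 4900 nM

Of the two exact numbers, the higher belongs to compound 1 at 25000 nM, and compound 3 lies clearly lower at 4900 nM. Compound 1 is therefore a weak inhibitor in this assay, with room for a change in either direction.

The next analogue is compound 4 `N=C(NC(=N)NC1CCCC1)Nc1ccc(F)c(F)c1`, which has not yet been measured. The structural change is cyclopentyl in place of isopropyl on an amine nitrogen.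

Among the measured compounds shown here, only one measured step connects two compounds directly: an at least 2.0-fold higher number from compound 1 to compound 2 (0.30 log units; that floor lies within the scatter). That step is hydrogen in place of fluoro on an aromatic carbon, and its floor lies within the scatter. It involves a different place from the amine nitrogen, so it gives no direct measure of the new change. For the measured compounds named here, no measured step covers a change of isopropyl on that nitrogen.

Going by the values given here, with no such step to draw on, no shift beyond the scatter is expected, only a slight lean towards a lower number. The expected change is a 1.7-fold lower number from compound 1 to compound 4 (0.22 log units; within the scatter). For compound 4 the estimated value is 15000 nM, with an expected range of 5000 nM to 40000 nM.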

Compound 4, half-maximal inhibitory concentration: 7200 nM
Compound 4: middle estimate off by 2.1-fold (0.32 log units), on the high side, within the range that was stated.
By their numbers in this assay, from the lowest: compounds 3 and 4 (each within the scatter of the next); then compound 1. At a limit, above all of these: compound 2.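

In this assay, among the compounds shown here, the change at the amine nitrogen gives the first step that lies beyond the scatter and is read between two exact numbers: a 3.5-fold lower number from compound 1 to compound 4 (0.54 log units; beyond the scatter), a modest gain with cyclopentyl in place of isopropyl. The earlier step, hydrogen in place of fluoro on an aromatic carbon, gave only a floor within the scatter, an at least 2.0-fold higher number from compound 1 to compound 2 (0.30 log units; that floor lies within the scatter), so it could not show whether any single change moves this series by a clear margin. That floor rests on the limit for compound 2, which plays no part in the new step: the limit of > 50000 nM in this assay, at which 1 of the 4 values shown sits.

For the compounds shown here, the single pair cannot separate the ring from the larger number of carbons, since cyclopentyl differs from isopropyl in both, and an open-chain pentyl group or a cyclohexyl ring on the same nitrogen would bear on that question. As far as these compounds go, it also remains open whether the same change on that nitrogen carries over to a core with a different aromatic substitution, such as the trifluoromethyl group of compound 3, or to a ring bearing a hydroxyl group.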